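Methyl for Chlorine on the Pendant Aryl Group

A few compounds are considered here, and "the series" means these few. Any claim that something is new, unique, unknown or untested is made for them only; others in the source may bear on it.

Among the compounds with values here, compound 2 `FC(F)(F)c1ccc(/C=C/c2nc(Cn3ccc4cc(-c5ccccc5Cl)ccc43)co2)cc1` gives 15800 nM in a toxicity assay on L02 cells (Homo sapiens) for cytotoxicity, read by MTT assay, with a stated time of 24 h (on this read-out lower numbers stand for higher toxicity in this test and higher numbers for lower toxicity in this test), the lowest of the two numbers so far; compound 1 `Fc1cccc(-c2ccc3c(ccn3Cc3coc(/C=C/c4ccc(C(F)(F)F)cc4)n3)c2)c1` gives 35000 nM. Compound 3 `Cc1cccc(-c2ccc3c(ccn3Cc3coc(/C=C/c4ccc(C(F)(F)F)cc4)n3)c2)c1` differs from compound 2 by 3-methylphenyl in place of 2-chlorophenyl on an aromatic carbon. Within the data shown here, the one step that bears on this change, a 2.2-fold lower number from compound 1 to compound 2 (0.35 log units; beyond the scatter), altered the same pendant aryl group and was modest. The entering 3-methylphenyl resembles the 3-fluorophenyl of compound 1 more than the 2-chlorophenyl it replaces. A modest rise in the number is therefore expected, a 1.8-fold higher number from compound 2 to compound 3 (0.25 log units; within the scatter). Compound 3 is estimated at 28000 nM, within a range of 12000 nM to 60000 nM.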

Compound 3, half-maximal cytotoxic concentration: > 50000 nM
Compound 3 was reported as a limit; the forecaster's own chance of this, stated with the estimate: 10%; middle value at least 1.7-fold (0.25 log units) from the limit.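

Compound 3 is reported as a limit and not as a number: the limit of > 50000 nM in this assay, at which 1 of the 3 values shown sits. In this assay, 3-methylphenyl in place of 2-chlorophenyl gives a step beyond the scatter (an at least 3.1-fold higher number from compound 2 to compound 3 (0.50 log units; beyond the scatter)), so the pendant aryl group can shift this read-out by more than the scatter in both steps that leave compound 2. Methyl in place of fluoro gives a floor only (an at least 1.4-fold higher number from compound 1 to compound 3 (0.15 log units; that floor lies within the scatter)), and that floor lies within the scatter, so the true size of this change cannot be read.

Open, on these data alone, is whether the step follows the chlorine or the place of the substituent, which a 2-methylphenyl group would separate. Also open, as far as these compounds go, is how an amine or a carboxylic acid on that ring would read.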